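Thiophen-2-yl in place of 4-(methylsulfanyl)phenyl in compound 1

The source may report more compounds than this note shows. Statements on the series, on what has been measured and on what is new or still open speak of the compounds shown alone.

In a functional assay on HeLa cells (Homo sapiens) for cytotoxicity, read by MTT assay, with a stated time of 48 h (on this read-out higher numbers stand for an effect only at larger amounts of compound and lower numbers for an effect already at smaller amounts), compound 1 `CSc1ccc(/C=N/n2c(Cc3ccc(S(C)(=O)=O)cc3)n[nH]c2=S)cc1` gives 50000 nM. Compound 2 `CS(=O)(=O)c1ccc(Cc2n[nH]c(=S)n2/N=C/c2ccc(Cl)cc2)cc1` gives 50000 nM, level with compound 1 at the digits shown. Compound 3 `CS(=O)(=O)c1ccc(Cc2n[nH]c(=S)n2/N=C/c2ccccc2F)cc1` gives > 100000 nM, which is a limit of the assay and not a number.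

The open question is compound 4 `CS(=O)(=O)c1ccc(Cc2n[nH]c(=S)n2/N=C/c2cccs2)cc1`, which differs from compound 1 by thiophen-2-yl in place of 4-(methylsulfanyl)phenyl on a carbon with a double bond to nitrogen. Among the compounds with values here, two measured steps bear on this change. Exchanging only the methylsulfanyl for chloro gave no change at the digits printed from compound 1 to compound 2 (within the scatter). Going by these compounds, the closer precedent, an exchange of the whole aromatic group, gave an at least 2.0-fold higher number from compound 1 to compound 3 (0.30 log units; that floor lies within the scatter), and its full size stays open. Within the data shown here, no measured compound carries a five-membered aromatic ring.

A small move towards higher numbers in this assay is therefore expected, an estimated 1.4-fold higher number from compound 1 to compound 4 (0.15 log units; within the scatter), which may not clear the scatter. The reading may also stop at the limit of > 100000 nM in this assay, at which 1 of the 3 values shown sits. Compound 4 is expected at 70000 nM, with an estimated range of 30000 nM to 150000 nM.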

Compound 4, half-maximal effective concentration: 100000 nM
For compound 4 the middle estimate is 1.4-fold (0.15 log units) below the measured one; the range from low to high includes it.
By their numbers in this assay, from the lowest: compounds 1, 2 and 4 (each within the scatter of the next).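

The thiophen-2-yl group shows that a five-membered aromatic ring with a hetero atom can stand on this carbon with a double bond to nitrogen and still give a reading in this assay that lies within the scatter of those of the six-membered aromatic rings. The exchange of the whole aromatic group now has a readable size, a 2.0-fold higher number from compound 1 to compound 4 (0.30 log units; within the scatter), and the same holds against the chlorinated ring, a 2.0-fold higher number from compound 2 to compound 4 (0.30 log units; within the scatter). Against the 2-fluorophenyl group the step is a number no higher from compound 3 to compound 4 (the limit leaves the size open). The value of compound 3 is a limit and not a number, so the size of that step cannot be read: the limit of > 100000 nM in this assay, at which 1 of the 4 values shown sits.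

Going by these compounds, whether any group on this carbon, such as a pyridine ring or a phenyl ring carrying an amine or a carboxylic acid, would move the reading beyond the scatter stays open. On these data alone, the effect of changes elsewhere on the shared core also stays open.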